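A few compounds are considered here, and "the series" means these few. Any claim that something is new, unique, unknown or untested is made for them only; others in the source may bear on it.

Of the compounds shown here, three with a shared core have been measured in an ADME assay for pharmacokinetics; a higher number here means that the compound lasts longer, a lower number that the compound disappears faster. Compound 1 `CC[C@H](c1ccc(O)cc1)[C@@H](CC)c1ccc(OCC(O)CBr)cc1`, which carries a 3-bromo-2-hydroxypropoxy group, gives 0.5 h. Compound 2 `CC[C@H](c1ccc(O)cc1)[C@@H](CC)c1ccc(OCC(O)CCl)cc1`, which carries 3-chloro-2-hydroxypropoxy instead, gives 0.5 h. Compound 3 `CC[C@H](c1ccc(O)cc1)[C@@H](CC)c1ccc(C(=O)CCl)cc1`, with (chloromethyl)carbonyl on that aromatic carbon, gives 0.5 h, which puts it level with the other two.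

The next compound, compound 4 `CC[C@H](c1ccc(O)cc1)[C@@H](CC)c1ccc(OCC(=O)CCl)cc1`, has ((chloromethyl)carbonyl)methoxy in place of the (chloromethyl)carbonyl of compound 3, on an aromatic carbon para to a large group: ((chloromethyl)carbonyl)methoxy in place of (chloromethyl)carbonyl on an aromatic carbon. Its side chain thus combines an ether oxygen, as in compounds 1 and 2, with the (chloromethyl)carbonyl of compound 3.

For the measured compounds named here, three measured steps bear on this change. Swapping the halogen shows no change at the digits printed from compound 1 to compound 2 (within the scatter). Exchanging the whole side group shows no change at the digits printed from compound 1 to compound 3 (within the scatter), and likewise no change at the digits printed from compound 2 to compound 3 (within the scatter). With all three steps inside the scatter, no step beyond the scatter is expected in this assay, in either direction, although three compounds are a small basis. The estimated outcome is no change at the digits printed from compound 3 to compound 4 (within the scatter). The expected half-life of compound 4 is 0.5 h, with an estimated range from 0.3 h to 0.9 h.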

Compound 4, half-life: 0.25 h
Compound 4: the middle estimate sits 2.0-fold (0.30 log units) above what was measured; the whole stated range lies above it.
By their numbers in this assay, from the lowest: compounds 4, 1, 2 and 3 (each within the scatter of the next).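

In this assay, ((chloromethyl)carbonyl)methoxy in place of (chloromethyl)carbonyl, on an aromatic carbon para to a large group, gives a 2.0-fold lower number from compound 3 to compound 4 (0.30 log units; within the scatter) and so adds a new side-chain change that stays inside the usual spread of repeat measurements. On the saturated chain carbon bound to an oxygen on an aromatic ring, (chloromethyl)carbonyl in place of 2-chloro-1-hydroxyethyl gives a 2.0-fold lower number from compound 2 to compound 4 (0.30 log units; within the scatter) and the same group in place of 2-bromo-1-hydroxyethyl gives a 2.0-fold lower number from compound 1 to compound 4 (0.30 log units; within the scatter) as well, so exchanging the hydroxyl-bearing carbon for a carbonyl within the ether chain also leaves the half-life inside that spread. Nothing available explains why these steps have the size they do.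

All four compounds carry a halogen-bearing side chain at this position, and every step among them lies within the scatter, so the position has only been probed within this narrow family. From the compounds shown here alone, how the half-life would respond to a carboxylic acid, an amine or a longer chain without a halogen on this aromatic carbon remains open.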